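The compounds below may be only part of what the source reports. "The series", "measured", "known", "first", "only" and "open" are said of these compounds alone.

Measured so far in an assay on HEK293 cells for displacement of a labelled ligand from Melanocortin receptor 4 (Homo sapiens); a lower number here means a stronger inhibitor, a higher number a weaker inhibitor:
compound 1 `COc1ccc(OCC(=O)N2CCN(c3ccc(C(F)(F)F)cc3[C@@H](N)CC(C)C)CC2)cc1` gives 3800 nM
compound 2 `CC(C)C[C@H](N)c1cc(C(F)(F)F)ccc1N1CCN(C(=O)CC(C)C(=O)c2ccc(Cl)cc2)CC1` gives 1100 nM
compound 3 `CC(C)C[C@H](N)c1cc(C(F)(F)F)ccc1N1CCN(C(=O)C(C)Cc2ccc(Cl)cc2)CC1` gives 47 nM

Compound 3 stands with the lowest number of the three. The nearest measured compound is compound 2, and the gap is a 23-fold lower number from compound 2 to compound 3 (1.37 log units; beyond the scatter); the furthest is compound 1, with an 81-fold lower number from compound 1 to compound 3 (1.91 log units; beyond the scatter). Both gaps are beyond the scatter, so compound 3 is the strongest binder of the three on these numbers.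

Compound 4 `CC(C)C[C@H](N)c1cc(C(F)(F)F)ccc1N1CCN(C(=O)CCC(=O)c2ccc(Cl)cc2)CC1` is the next member. Its difference from compound 3: 2-((4-chlorophenyl)carbonyl)ethyl in place of 1-(4-chlorobenzyl)ethyl on a carbonyl carbon

Going by the values given here, the step that bears on this change is the one from compound 2 to compound 3, where the 2-((4-chlorophenyl)carbonyl)propyl group gave way to 1-(4-chlorobenzyl)ethyl and the number fell by a 23-fold lower number from compound 2 to compound 3 (1.37 log units; beyond the scatter). Compound 4 moves back towards a chain carrying a (4-chlorophenyl)carbonyl unit, so the expectation is a step in the opposite direction, of roughly that size. Compound 2 is the closest measured anchor for such a chain, and compound 4 is expected to land near it; the estimated step is a 21-fold higher number from compound 3 to compound 4 (1.33 log units; beyond the scatter). For compound 4 in this assay the estimate is 1000 nM, within a range from 300 nM to 3500 nM.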

Compound 4, inhibition constant: 820 nM
Estimate against measurement, compound 4: 1.2-fold (0.09 log units) above; measured number inside the range.
By their numbers in this assay, from the lowest: compound 3; then compounds 4 and 2 (each within the scatter of the next); then compound 1.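

In this assay, the methyl on the saturated chain carbon bound to a carbonyl carbon and a saturated chain carbon has no readable effect once the (4-chlorophenyl)carbonyl unit is in the chain: hydrogen in its place gives a 1.3-fold lower number from compound 2 to compound 4 (0.13 log units; within the scatter), which is within the scatter. The chain without that methyl still stays far from compound 3, with a 17-fold higher number from compound 3 to compound 4 (1.24 log units; beyond the scatter), so the gap seen earlier with compound 2 is not tied to the methyl of compound 2. It also keeps a gain over the 4-methoxyphenoxy side chain, with a 4.6-fold lower number from compound 1 to compound 4 (0.67 log units; beyond the scatter), and no measurement on hand offers a reason for any of these steps.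

Compound 3 and compound 4 differ both in the chain carbonyl and in the methyl, so the compounds shown do not separate the two as the source of the large step. As far as these compounds go, a 3-(4-chlorophenyl)propyl chain on the same carbonyl carbon, or a hydroxyl in place of the chain carbonyl, would bear on that question, and how either reads in this assay remains open.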